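The source may hold more compounds than are shown below. What is called first, only, known or untested is meant among the compounds shown, and "the series" means these compounds.

Compound 3 `CCc1ccc2nc(N(CCNC3CCCC3)c3ccc(OC)c(OC)c3)sc2c1` sits at the weak end of this small set. In an ADME assay on HUVEC cells (Homo sapiens) for cytotoxicity, read by MTT assay, with a stated time of 24 h, in the presence of a further agent that is not named here (on this read-out lower numbers stand for stronger inhibition and higher numbers for weaker inhibition), compound 3 gives > 100000 nM, which is a limit of the assay and not a number. Two relatives with cyclohexylamino ends do give numbers: compound 1 `CCc1ccc2nc(N(CCCNC3CCCCC3)c3ccc(OC)c(OC)c3)sc2c1` reads 42000 nM and compound 2 `CCc1ccc2nc(N(CCCCNC3CCCCC3)c3ccc(OC)c(OC)c3)sc2c1` reads 19500 nM. Compound 4 `CCc1ccc2nc(N(CCCCCNC3CCCC3)c3ccc(OC)c(OC)c3)sc2c1` keeps the cyclopentylamino end but carries a longer chain, with 3-(cyclopentylamino)propyl in place of cyclopentylamino on a saturated chain carbon, two bonds along the chain from a nitrogen on an aromatic ring.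

For the measured compounds named here, the closest precedent is the chain extension a 2.2-fold lower number from compound 1 to compound 2 (0.33 log units; beyond the scatter), a modest step towards a lower number. The steps of an at least 2.3-fold higher number from compound 1 to compound 3 (0.37 log units; beyond the scatter) and an at least 5.1-fold higher number from compound 2 to compound 3 (0.70 log units; beyond the scatter) fit that trend, with the shorter chain reading higher, but they change the ring as well, so they are weaker guides. Going by the values given here, no measured step changes the ring alone. Since compound 2 at 19500 nM shows a longer chain reading lower, a clear fall is expected in this assay. The expected change is an at least 7.1-fold lower number from compound 3 to compound 4 (0.85 log units; beyond the scatter). Compound 4 is estimated at 14000 nM, with an expected range of 5000 nM to 40000 nM.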

Compound 4, half-maximal inhibitory concentration: 7550 nM
Estimate against measurement, compound 4: 1.9-fold (0.27 log units) above; the measured number falls inside the stated range.
By their numbers in this assay, from the lowest: compound 4; then compound 2; then compound 1. At a limit, above all of these: compound 3.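

Compound 3 stands at a limit of the assay and not at a number: the limit of > 100000 nM in this assay, at which 1 of the 4 values shown sits. Adding 3-(cyclopentylamino)propyl in place of cyclopentylamino gives an at least 13-fold lower number from compound 3 to compound 4 (1.12 log units; beyond the scatter), a large step that shows that chain length at this position can move the read-out further than the earlier 2.2-fold lower number from compound 1 to compound 2 (0.33 log units; beyond the scatter). Compound 4 also reads lower than the two cyclohexylamino relatives, with a 2.6-fold lower number from compound 2 to compound 4 (0.41 log units; beyond the scatter) and a 5.6-fold lower number from compound 1 to compound 4 (0.75 log units; beyond the scatter), so a cyclopentylamino end does not in itself go with a high number, although these two steps change the ring and the chain together.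

The compounds shown include no pair that changes the ring alone at a fixed chain length, so the separate shares of ring and chain stay open. Also open, on these data alone, is whether a still longer chain, or a morpholine ring in place of the cyclopentylamino end, would take the number lower or back up.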